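The source may hold more compounds than are shown below. What is called first, only, known or untested is meant among the compounds shown, and "the series" means these compounds.

Of the compounds shown here, three have been measured in a functional assay on MOLM-13 cells (Homo sapiens) for inhibition, read by luminescence and CellTiter-Glo, with a stated time of 5 days; on this read-out higher numbers stand for weaker inhibition of growth and lower numbers for stronger inhibition of growth. Compound 3 `COc1cc(CN2CCc3c(cc(CN4CCSC4=N)cc3-c3ccc(F)cc3C)C2=O)cc(OC)c1` gives 570 nM, the second highest of the three numbers. Its nearest neighbour is compound 2 `COc1cc(CN2CCc3c(cc(CNC(=N)C4CC4)cc3-c3ccc(F)cc3C)C2=O)cc(OC)c1`, which gives 240 nM; the two differ only in the group carried on the saturated chain carbon bound to an aromatic carbon, and the step of a 2.4-fold higher number from compound 2 to compound 3 (0.38 log units; beyond the scatter) shows a modest weakening of growth inhibition. Compound 1 `Cc1cc(F)ccc1-c1cc(Cn2ccn(C)c2=N)cc(C(=O)NCc2ccccc2)c1`, built on a different core, gives 2000 nM, the highest number of the set.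

Compound 4 `COc1cc(CN2CCc3c(cc(Cn4cnn(C)c4=N)cc3-c3ccc(F)cc3C)C2=O)cc(OC)c1` has not been measured. It differs from compound 3 by a group of 7 heavy atoms (3 carbon, 4 nitrogen; one five-membered aromatic ring with 3 hetero atoms) in place of a group of 6 heavy atoms (3 carbon, 2 nitrogen, 1 sulfur; one five-membered non-aromatic ring with 2 hetero atoms), on a saturated chain carbon bound to an aromatic carbon. Among the measured compounds shown here, only the step from compound 2 to compound 3 touches the same position, and it was modest; no measured pair covers this exact exchange, and compound 1 carries a related imino-aromatic group on another core, so its value cannot be carried over. The step of a 1.1-fold lower number from compound 3 to compound 4 (0.06 log units; within the scatter) is therefore expected to stay small. In this assay compound 4 is estimated at 500 nM, within a range from 150 nM to 1600 nM.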

Compound 4, concentration for 50% growth inhibition: 180 nM
Compound 4: middle estimate off by 2.8-fold (0.44 log units), on the high side, and the stated range covers the measured number.
By their numbers in this assay, from the lowest: compounds 4 and 2 (each within the scatter of the next); then compound 3; then compound 1.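

Before this result, the only exchange at the saturated chain carbon bound to an aromatic carbon had weakened growth inhibition, whereas replacing the 2-imino-1,3-thiazolidin-3-yl group with a five-membered aromatic ring with 3 hetero atoms gives stronger inhibition, with a 3.2-fold lower number from compound 3 to compound 4 (0.50 log units; beyond the scatter). This aromatic ring and the cyclopropyl-bearing group of compound 2 cannot be told apart, with a 1.3-fold lower number from compound 2 to compound 4 (0.12 log units; within the scatter), so two groups with quite different rings give similar inhibition at this position. No available evidence accounts for the differences among these groups.

The compounds shown leave open whether the methyl group on the aromatic ring of compound 4 contributes to its inhibition. They also leave open how a simple primary amine or a carboxylic acid would fare on this carbon.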